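This account rests on a few compounds, and the source may have more. Where it says the series, first, only, none or still open, it means among the compounds named here.

Of the compounds shown here, two have been measured in a functional assay on MDA-MB-435 cells (Homo sapiens) for cytotoxicity, read by sulforhodamine B assay, with a stated time of 48 h; a higher number here means a weaker inhibitor of growth, a lower number a stronger inhibitor of growth. Compound 1 `ClCc1ccc(Cn2cnc3c(Cl)ncnc32)cc1` gives 4360 nM in this assay. Going by the values given here, compound 2 `ClCc1ccccc1Cn1cnc2c(Cl)nc(Cl)nc21` gives 3230 nM in this assay, the lowest of the two numbers, although the number for compound 1 lies within the scatter of it; the two compounds differ in more than one place, so no single step is read from them. Compound 3 `ClCc1ccccc1Cn1cnc2c(Cl)ncnc21` has not yet been measured. The change from compound 2 to compound 3 is hydrogen in place of chloro on an aromatic carbon, a hydrogen in place of chloro on an aromatic carbon. Among the compounds with values here, no measured step of this kind is available. Compound 3 shares its core with compound 1, and compound 1 gives 4360 nM in this assay, which supports an expectation close to compound 2. The expected step is a 1.2-fold higher number from compound 2 to compound 3 (0.09 log units; within the scatter), nothing beyond the scatter. Compound 3 is estimated at 4000 nM, with a range from 1500 nM to 12000 nM.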

Compound 3, concentration for total growth inhibition: 9550 nM
Estimate against measurement, compound 3: 2.4-fold (0.38 log units) below, within the range that was stated.
By their numbers in this assay, from the lowest: compounds 2 and 1 (each within the scatter of the next); then compound 3.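

In this assay, going by these compounds alone, the aromatic carbon between two ring nitrogen atoms now gives the series its only readable step: hydrogen in place of chloro gives a 3.0-fold higher number from compound 2 to compound 3 (0.47 log units; beyond the scatter). Compounds 1 and 2 could not show this, as they differ in more than one place. The step is modest but beyond the scatter, so this position is not silent in this read-out, and the chloro group goes with the lower number in this one pair. Nothing available bears on why the number moves with this change.

From the compounds shown here alone, only chloro and hydrogen are compared at this position, so how an amine or a methoxy group there would read stays open. Going by these compounds, whether the step holds with the chloromethyl group placed as in compound 1 also remains open.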